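The source may hold more compounds than are shown below. What is called first, only, known or untested is meant among the compounds shown, and "the series" means these compounds.

Three related compounds have been measured in an ADME assay on MRC5 cells (Homo sapiens), read by MTT assay, with a stated time of 72 h (on this read-out higher numbers stand for weaker inhibition and lower numbers for stronger inhibition), and little separates them. Compound 1 `CSc1ncnc2c1c(-c1cccs1)cn2[C@@H]1O[C@H](CO)[C@@H](O)[C@H]1O` gives > 100000 nM, which is a limit of the assay and not a number. Compound 2 `Nc1nc(N)c2c(-c3ccco3)cn([C@@H]3O[C@H](CO)[C@@H](O)[C@H]3O)c2n1` gives > 100000 nM, which is likewise a limit. For the measured compounds named here, compound 3 `COc1nc(N)nc2c1c(-c1ccco1)cn2[C@@H]1O[C@H](CO)[C@@H](O)[C@H]1O` gives 89700 nM, the only real number among the three. The whole set therefore crowds against (the limit of > 100000 nM in this assay, at which 2 of the 3 values shown sit).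

Compound 4 `COc1nc(N)nc2c1c(-c1ccoc1)cn2[C@@H]1O[C@H](CO)[C@@H](O)[C@H]1O` has not yet been measured. It has the same atoms as compound 3, joined differently: furan-3-yl in place of furan-2-yl on an aromatic carbon. The furan stays, and only the ring atom through which it is attached changes, so furan-3-yl stands in place of furan-2-yl.

Going by the values given here, the only measured step, an at least 1.1-fold lower number from compound 2 to compound 3 (0.04 log units; that floor lies within the scatter), puts methoxy in place of amino on an aromatic carbon, and it lies within the scatter. Among the compounds with values here, it concerns a different place in the molecule, so it offers only indirect guidance, and no measured step touches the furan itself. With so little movement seen, no change beyond the scatter is expected in this assay. The expected step, a 1.1-fold lower number from compound 3 to compound 4 (0.02 log units; within the scatter), is an estimate that stays within that scatter. For compound 4 the estimated value is 85000 nM, with an expected range from 40000 nM to 100000 nM. A report of only the assay's limit would also fit this expectation.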

Compound 4, half-maximal inhibitory concentration: > 100000 nM
Compound 4: only a limit was reported (the forecaster's own chance of this, stated with the estimate: 40%); middle value at least 1.1-fold (0.07 log units) from the limit.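

In this assay, for the compounds shown here, the first measured change at the furan gives an at least 1.1-fold higher number from compound 3 to compound 4 (0.04 log units; that floor lies within the scatter). Moving the point of attachment from furan-2-yl to furan-3-yl keeps the same atoms and the same counts of hydrogen-bond donors and acceptors, and on this aromatic carbon it produces no shift that can be told apart from the scatter. The step is only a floor, so a larger difference is not ruled out, and this change did not bring the series away from the edge of what the assay can report: the limit of > 100000 nM in this assay, at which 3 of the 4 values shown sit.

Going by these compounds, whether a different kind of group on this aromatic carbon, such as a phenyl ring, an amine or a carboxylic acid, would give a number clearly lower than those seen here remains open. Also open, on these data alone, is whether furan-2-yl and furan-3-yl would differ on a core that carries an ethoxy group or a longer chain in place of methoxy.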